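The source may hold more compounds than are shown below. What is called first, only, known or untested is meant among the compounds shown, and "the series" means these compounds.

Working notes on the cytotoxicity side of the series. All four compounds share one core and differ only in the anilide portion: compound 1 `Cc1ccc(NC(=O)CCc2cccc3c2B(O)OC3)cc1` carries a methyl on the aniline ring, compound 2 `O=C(CCc1cccc2c1B(O)OC2)Nc1ccccc1-c1ccccc1` a phenyl, compound 3 `O=C(CCc1cccc2c1B(O)OC2)Nc1cccc(-c2cccc(Cl)c2)c1` a 3-chlorophenyl, and compound 4 `CC(=O)c1cccc(-c2cccc(NC(=O)CCc3cccc4c3B(O)OC4)c2)c1`, not yet measured, a 3-acetylphenyl.

In an ADME assay on WI-38 cells (Homo sapiens) for cytotoxicity, read by MTT assay, with a stated time of 72 h (a higher number here means a weaker inhibitor, a lower number a stronger inhibitor), compound 1 returns a limit of the assay, > 100000 nM, and no number (the limit of > 100000 nM in this assay, at which 1 of the 3 values shown sits). In this assay compound 2 gives 77000 nM. In this assay compound 3 gives 58000 nM, the lower of the two numbers shown, but compound 2 sits within the scatter of it, so nothing sets the two apart. Across the three, the numbers all sit high, and no structural change among them moves the read-out beyond the scatter.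

The step to compound 4 is acetyl in place of chloro on an aromatic carbon. Within the data shown here, no measured pair shows this change. The expectation for the step from compound 3 to compound 4 in this assay is none beyond the scatter, with the estimate of a 1.2-fold higher number from compound 3 to compound 4 (0.08 log units; within the scatter) reflecting that. Compound 4 is therefore estimated at 70000 nM, between 30000 nM and 150000 nM, with a fair chance that only a limit is reported.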

Compound 4, half-maximal inhibitory concentration: 2200 nM
Estimate against measurement, compound 4: 32-fold (1.50 log units) above; measured number outside the range, below it.
By their numbers in this assay, from the lowest: compound 4; then compounds 3 and 2 (each within the scatter of the next). At a limit, above all of these: compound 1.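

In this assay, the change from 3-chlorophenyl to 3-acetylphenyl gives a 26-fold lower number from compound 3 to compound 4 (1.42 log units; beyond the scatter), the one step beyond the scatter among the compounds shown. The earlier compounds shown here all gave high numbers that did not separate from one another, so they gave no sign that this aromatic carbon, meta to a large group, could respond so strongly to a single substituent change. The change brings in more heavy atoms, a double bond outside the aromatic rings and a hydrogen-bond acceptor together, and no measured property among the data shown explains the step.

Among these compounds, with only this one pair, the feature of the acetyl group that matters cannot be separated from the others, and it remains unknown whether a carboxylic acid, a primary amide or a longer acyl chain such as propanoyl on the same carbon would give a similar drop. From the compounds shown here alone, it also remains open whether the acetyl group would have the same effect in a compound that differs elsewhere, so the step holds for this one pair and not yet as a pattern across the series.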